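Replacing 2-aminobutoxy on the way to compound 4

The source may report more compounds than this note shows. Statements on the series, on what has been measured and on what is new or still open speak of the compounds shown alone.

Measured in a functional assay on MCF7 cells (Homo sapiens) for inhibition, read by fluorescence, with a stated time of 72 h; a higher number here means a weaker inhibitor, a lower number a stronger inhibitor:
Compound 1 `CCCn1cnc2c(NC(=N)N)nc(N)nc21`: 36500 nM
Compound 2 `CC(C)n1cnc2c(NC(=N)N)nc(NCCCO)nc21`: 8800 nM
Compound 3 `CC[C@@H](N)COc1nc(NC(=N)N)c2ncn(C(C)C)c2n1`: > 100000 nM (a limit, not a number)

Compound 3 stands at the limit of > 100000 nM in this assay, at which 1 of the 3 values shown sits. Compound 4 `CC(C)[C@@H](CO)Nc1nc(NC(=N)N)c2ncn(C(C)C)c2n1` differs from it at one place on the shared core: (1-(hydroxymethyl)-2-methylpropyl)amino in place of 2-aminobutoxy on an aromatic carbon. Here (1-(hydroxymethyl)-2-methylpropyl)amino takes the place of 2-aminobutoxy.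

Among the compounds with values here, the one measured step that bears on this change is an at least 11-fold higher number from compound 2 to compound 3 (1.05 log units; beyond the scatter). That step is large and lies beyond the scatter, and it also removed an amino-linked group in favour of 2-aminobutoxy. The change to compound 4 goes the other way, and its entering group resembles the (3-hydroxypropyl)amino of compound 2, which gives 8800 nM. A large step toward a lower number in this assay is therefore expected, though no measurement covers the branched chain of compound 4. The expected step is an at least 6.6-fold lower number from compound 3 to compound 4 (0.82 log units; beyond the scatter). For compound 4 the estimate is 15000 nM, with an expected range from 4000 nM to 60000 nM.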

Compound 4, half-maximal inhibitory concentration: 2100 nM
The estimate for compound 4 lay 7.1-fold (0.85 log units) above the measured number; measured number below the stated range.
By their numbers in this assay, from the lowest: compound 4; then compound 2; then compound 1. At a limit, above all of these: compound 3.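

In this assay, (1-(hydroxymethyl)-2-methylpropyl)amino on this aromatic carbon gives a measurable value where 2-aminobutoxy did not, with an at least 47-fold lower number from compound 3 to compound 4 (1.67 log units; beyond the scatter). Compound 3 stands at a limit of the assay, not at a number: the limit of > 100000 nM in this assay, at which 1 of the 4 values shown sits. The new result also shows that the amino-linked groups at this position differ from each other, since the branched chain goes past the straight one, with a 4.2-fold lower number from compound 2 to compound 4 (0.62 log units; beyond the scatter).

The change from compound 3 to compound 4 swaps the oxygen link for a nitrogen link and the chain's amine for a hydroxyl together, so the compounds shown do not separate the two; 2-hydroxybutoxy or (2-aminobutyl)amino would fall between them. Also open, going by these compounds, is how the opposite stereocentre, or a longer chain on that nitrogen, would read in this assay.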